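This account rests on a few compounds, and the source may have more. Where it says the series, first, only, none or still open, it means among the compounds named here.

In a functional assay on MV4-11 cells (Homo sapiens) for antiproliferative activity, read by CCK-8 assay, with a stated time of 72 h (on this read-out higher numbers stand for weaker inhibition and lower numbers for stronger inhibition), compound 1 `Cn1cc(-c2ccccc2Oc2ccccc2)c2cc(C(=O)NCCCC(=O)NO)[nH]c2c1=O` gives 380 nM and compound 2 `Cn1cc(-c2ccccc2Oc2ccccc2)c2cc(C(=O)NCCCCC(=O)Nc3ccccc3N)[nH]c2c1=O` gives 240 nM on the same core. Compound 2 therefore stands level with compound 1 within the scatter, and the two cannot be ranked. Going by the values given here, the only measured step is a 1.6-fold lower number from compound 1 to compound 2 (0.20 log units; within the scatter) and it places ((2-aminophenyl)carbamoyl)methyl where hydroxycarbamoyl stood, on a saturated chain carbon, three bonds along the chain from an amide-type nitrogen.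

Compound 3 `Cn1cc(-c2ccccc2Oc2ccccc2)c2cc(C(=O)NCCCCCC(=O)Nc3ccccc3N)[nH]c2c1=O` has not yet been measured. Its difference from compound 2 is this: ((2-aminophenyl)carbamoyl)methyl in place of (2-aminophenyl)carbamoyl on a saturated chain carbon, four bonds along the chain from an amide-type nitrogen (cut one bond further out, ((2-aminophenyl)carbamoyl)methyl to 2-((2-aminophenyl)carbamoyl)ethyl). Among the compounds with values here, no measured step isolates this change, so the single step from compound 1 to compound 2 bears on it only indirectly, and that step stayed within the scatter. On this thin evidence the expected 1.1-fold lower number from compound 2 to compound 3 (0.04 log units; within the scatter) is no shift beyond the scatter, in either direction. In this assay compound 3 is expected at 220 nM with an estimated range from 90 nM to 520 nM around that figure.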

Compound 3, half-maximal inhibitory concentration: 70 nM
Beside the measured number, compound 3's estimate is 3.1-fold (0.50 log units) above it; the whole stated range lies above it.
By their numbers in this assay, from the lowest: compound 3; then compounds 2 and 1 (each within the scatter of the next).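

Going by these compounds alone, with ((2-aminophenyl)carbamoyl)methyl in place of (2-aminophenyl)carbamoyl on a saturated chain carbon, four bonds along the chain from an amide-type nitrogen, this assay shows a 3.4-fold lower number from compound 2 to compound 3 (0.54 log units; beyond the scatter) and so gives the first change that lies beyond the scatter. The compounds with the (2-aminophenyl)carbamoyl end thus respond to the chain that carries it, and the swap of hydroxycarbamoyl for 2-((2-aminophenyl)carbamoyl)ethyl also gives a 5.4-fold lower number from compound 1 to compound 3 (0.73 log units; beyond the scatter) in the same assay, whereas the earlier step from compound 1 to compound 2 could not be told from scatter. No evidence is at hand that would explain this gain.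

A longer chain ending in the same (2-aminophenyl)carbamoyl group is not among the compounds shown, so it remains open whether the numbers keep falling as the chain grows or whether compound 3 already sits near the best length. Hydroxycarbamoyl on the chain of compound 3 is also absent, which leaves the parts played by chain length and by the end group in the step from the first compound unseparated.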